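Compound 3 and the Move to a Cyclohexyl Amine

A few compounds are considered here, and "the series" means these few. Any claim that something is new, unique, unknown or untested is made for them only; others in the source may bear on it.

Compound 1 `O=C1C=C(NCc2ccccc2)C(=O)c2c1nc1n2[C@H]2OC[C@@H](O)[C@H]2OC1` gives > 8000 nM as a limit
Compound 2 `O=C1C=C(N2CCC2)C(=O)c2c1nc1n2[C@H]2OC[C@@H](O)[C@H]2OC1` gives > 16000 nM as a limit
Compound 3 `O=C1C=C(Nc2ccccc2F)C(=O)c2c1nc1n2[C@H]2OC[C@@H](O)[C@H]2OC1` gives 3640 nM as a measured number

In a functional assay on MCF7 cells (Homo sapiens) for inhibition, read by sulforhodamine B assay (on this read-out higher numbers stand for weaker inhibition and lower numbers for stronger inhibition), compound 3 stands out as the only one of the three with a number, at 3640 nM on this read-out. The other two values are limits. The next compound is compound 4 `O=C1C=C(NC2CCCCC2)C(=O)c2c1nc1n2[C@H]2OC[C@@H](O)[C@H]2OC1` and its change is cyclohexyl in place of 2-fluorophenyl on an amine nitrogen on an amine nitrogen. Going by the values given here, two measured steps bear on this: an at least 2.1-fold lower number from compound 1 to compound 3 (0.34 log units; beyond the scatter) and an at least 4.3-fold lower number from compound 2 to compound 3 (0.64 log units; beyond the scatter) are both gains on arriving at compound 3. Neither involves cyclohexyl, so they guide the expectation only loosely. Compound 4 gives up the 2-fluorophenyl, and the gain seen in an at least 2.1-fold lower number from compound 1 to compound 3 (0.34 log units; beyond the scatter) is therefore expected to be largely reversed. The expected change is a 2.2-fold higher number from compound 3 to compound 4 (0.34 log units; beyond the scatter) in this assay as estimated here, towards weaker inhibition, and a limit may be all that is reported. Compound 4 is estimated at 8000 nM with an expected range from 3000 nM to 20000 nM at this stage.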

Compound 4, half-maximal inhibitory concentration: > 8000 nM
Compound 4 gave a limit, no number (the forecaster's own chance of this, stated with the estimate: 40%); the middle value sits exactly at the limit.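

The new step isolates the group on the amine nitrogen: in this assay, cyclohexyl in place of 2-fluorophenyl gives an at least 2.1-fold higher number from compound 3 to compound 4 (0.34 log units; beyond the scatter). Going by these compounds alone, until now, the only measured number belonged to the compound with the 2-fluorophenyl, and this step shows that a six-membered carbon ring on that nitrogen does not by itself keep the number at that level, since the non-aromatic ring of compound 4 reaches only a limit. The steps to compound 4 from compound 1 and from compound 2 cannot be read, as both ends of each are limits.

The change removes the fluorine and the aromatic ring together, so the compounds shown do not tell which of the two carries the step; a plain phenyl on the same amine nitrogen would separate them. Going by these compounds, how far the true value of compound 4 lies past its limit also stays open.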